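A Third Aryl Group on the Sulfonyl Sulfur

This account rests on a few compounds, and the source may have more. Where it says the series, first, only, none or still open, it means among the compounds named here.

Compound 1 `COc1ccc(-c2cc(=O)c3c(OC)cc(OC)cc3n2S(=O)(=O)c2ccc([N+](=O)[O-])cc2)cc1` and compound 2 `COc1ccc(-c2cc(=O)c3c(OC)cc(OC)cc3n2S(=O)(=O)c2cc(F)c(F)c(F)c2)cc1` share a core and differ only in the group on the sulfonyl sulfur. In an ADME assay on BJ cells (Homo sapiens) for antiproliferative activity, with a stated time of 72 h (a higher number here means that more compound is needed for the effect, a lower number that less compound is needed), compound 1 gives > 29300 nM, which is a limit and not a number. Compound 2 gives > 65500 nM, which is also a limit, so it stands without a number of its own. Compound 3 `COc1ccc(-c2cc(=O)c3c(OC)cc(OC)cc3n2S(=O)(=O)c2ccc(C)cc2)cc1` carries 4-methylphenyl in place of 3,4,5-trifluorophenyl on a sulfonyl sulfur. Among the compounds with values here, the only measured step at this place is a step that the two limits leave unreadable from compound 1 to compound 2. It offers no size to carry over and no direction to follow, so another limit in the same region of this assay is expected. Compound 3 is estimated at 50000 nM, with an expected range from 15000 nM to 100000 nM. The expected change is an at least 1.3-fold lower number from compound 2 to compound 3 (0.11 log units; that floor lies within the scatter), an estimate with no firm direction.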

Compound 3, half-maximal effective concentration: > 44800 nM
Compound 3: a limit, no number; the forecaster's own chance of this, stated with the estimate: 80%; the middle value lies beyond the limit too.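

Compound 3 gives only a limit and not a number, as do compound 1 and compound 2, so no step among these three compounds can be read. The compounds shown leave open which group on the sulfonyl sulfur, if any, would give a readable number in this assay.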